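This account rests on a few compounds, and the source may have more. Where it says the series, first, only, none or still open, it means among the compounds named here.

Compound 1: `COc1cccc(OC2=C(Oc3cccc(OC)c3)C(=O)c3c(OC)ccc(OC)c3C2=O)c1`, 160 nM
Compound 2: `COc1cccc(OC2=C(Cl)C(=O)c3c(OC(C)=O)ccc(OC(C)=O)c3C2=O)c1`, 200 nM
Compound 3: `COc1cc(OC)cc(OC2=C(Cl)C(=O)c3c(OC)ccc(OC)c3C2=O)c1`, 120 nM

These three compounds were measured in a functional assay on HL-60 cells (Homo sapiens) for cytotoxicity; a lower number here means a stronger inhibitor, a higher number a weaker inhibitor. Compound 3 gives the lowest of the three numbers, yet its gaps to compound 1 and to compound 2 are within the usual scatter of repeated measurements, so no order among them can be read from these values. Compound 4, `COc1cccc(OC2=C(Cl)C(=O)c3c(OC)ccc(OC)c3C2=O)c1`, has not been measured. It differs from compound 3 in one place: hydrogen in place of methoxy on an aromatic carbon. For the measured compounds named here, no step between measured compounds mirrors this change. Compound 1 carries a single methoxy on its aryloxy ring, though it differs from compound 3 elsewhere as well. In this assay compound 1 gives 160 nM, close to compound 3. The step is therefore expected to be small, a 1.3-fold higher number from compound 3 to compound 4 (0.10 log units; within the scatter), with no direction beyond the scatter. Compound 4 is estimated at 150 nM, between 60 nM and 400 nM.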

Compound 4, half-maximal inhibitory concentration: 440 nM
Compound 4: middle estimate off by 2.9-fold (0.47 log units), on the low side, outside the stated range (above it).
By their numbers in this assay, from the lowest: compounds 3, 1 and 2 (each within the scatter of the next); then compound 4.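

In this assay, for the compounds shown here, this aromatic carbon proves sensitive to the change: hydrogen in place of methoxy gives a 3.7-fold higher number from compound 3 to compound 4 (0.56 log units; beyond the scatter), a step beyond the scatter that the earlier compounds could not show. Chloro in place of 3-methoxyphenoxy on the double-bonded ring carbon gives a 2.8-fold higher number from compound 1 to compound 4 (0.44 log units; beyond the scatter), so compound 4 stands apart from both of its single-change neighbours. No evidence shown accounts for either step.

On these data alone, whether an amine or a longer ether chain at the aromatic carbon would match methoxy remains open. So does whether a carboxylic acid would be tolerated there.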